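The source may hold more compounds than are shown below. What is called first, only, known or untested is meant among the compounds shown, and "the series" means these compounds.

Measured compounds in an ADME assay on the whole organism (plasma, Macaca fascicularis) for protein binding, read by LC-MS, using equilibrium dialysis and cassette dosing, with a stated time of 24 h, at a dose of 1 mg/kg by the oral route; a higher number here means a larger unbound share of the compound, a lower number a smaller unbound share:
compound 1 `CCCCN(c1nc2c(NC(C)=O)cccc2o1)[C@H](C)c1ccc(-c2ccccc2-c2nnn[nH]2)cc1` gives 0.00102
compound 2 `C[C@H](c1ccc(-c2cc(F)ccc2-c2nc(=O)o[nH]2)cc1)N(CC1CC1)c1nc2c(C(=O)O)cccc2o1` gives 0.0000977
compound 3 `C[C@H](c1ccc(-c2ccccc2-c2nc(=O)o[nH]2)cc1)N(CC1CC1)c1nc2c(C(=O)O)cccc2o1` gives 0.0000851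

Compound 1 stands highest of the three numbers in this assay; compound 2 lies a full step below it and compound 3 a little further, both beyond the scatter. Among the measured compounds shown here, compounds 2 and 3 differ from compound 1 in several places at once, so no single step connects them to compound 1; only their two values can be set beside it. For the measured compounds named here, the one step, a 1.1-fold lower number from compound 2 to compound 3 (0.06 log units; within the scatter), concerns a change on the other side of the molecule and lies within the scatter, so it says nothing about the change at hand.

Compound 4 `CCCCN(c1nc2c(C(=O)NS(C)(=O)=O)cccc2o1)[C@H](C)c1ccc(-c2ccccc2-c2nnn[nH]2)cc1` is the next compound to be measured. It differs from compound 1 as follows: (methylsulfonyl)carbamoyl in place of acetamido on an aromatic carbon. Going by the values given here, no measured step bears directly on this exchange, so the expectation rests on the position of compound 1 and the lower values of compounds 2 and 3. A downward step is expected in this assay, a 2.6-fold lower number from compound 1 to compound 4 (0.41 log units; beyond the scatter), of a size that may reach beyond the scatter. For compound 4 the expected unbound fraction is 0.0004, with a range from 0.0001 to 0.0015.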

Compound 4, unbound fraction: 0.00103
The estimate for compound 4 lay 2.6-fold (0.41 log units) below the measured number; the range from low to high includes it.
By their numbers in this assay, from the lowest: compounds 3 and 2 (each within the scatter of the next); then compounds 1 and 4 (each within the scatter of the next).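

In this assay, among the compounds shown here, (methylsulfonyl)carbamoyl in place of acetamido on this aromatic carbon, ortho to a fused ring and meta to a fused ring, gives a 1.0-fold higher number from compound 1 to compound 4 (0.00 log units; within the scatter), the first reading of a single change at this position. The exchange takes the substituent from 4 heavy atoms to 7 and from 1 hydrogen-bond acceptor to 3, with 1 hydrogen-bond donor and no net charge on both sides, yet the unbound fraction of the pair cannot be told apart. So, for this pair on the core of compound 1, this larger group is tolerated at this position without a measurable shift in this read-out, although no measurement in hand gives a reason for that.

For the compounds shown here, the gap between compound 1 and compounds 2 and 3 remains unassigned: those two differ from compound 1 in several places at once, and no single step ties that gap to any one group. Going by these compounds alone, it also remains open whether the unbound fraction stays this flat with an amine or a hydroxyl group on this aromatic carbon, since only one exchange at this position can be read.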